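A few compounds are considered here, and "the series" means these few. Any claim that something is new, unique, unknown or untested is made for them only; others in the source may bear on it.

Measured so far in a functional assay on A549 cells (Homo sapiens) for inhibition, read by MTT assay, with a stated time of 72 h; on this read-out higher numbers stand for weaker inhibition and lower numbers for stronger inhibition:
- compound 1 `O=C1/C(=C\c2ccccc2)c2c(ncn2COCc2ccccc2)CCN1Cc1ccccc1`: 9900 nM
- compound 2 `O=C1/C(=C\c2ccccc2)c2c(ncn2COCc2ccccc2)CCN1Cc1ccc(-c2ccccc2)cc1`: 18300 nM

Not yet measured:
- compound 3 `COc1ccc(CN2CCc3ncn(COCc4ccccc4)c3/C(=C/c3ccccc3)C2=O)cc1`

Compound 2 can be compared only with compound 1, and the two values lie within the scatter of each other, with a 1.8-fold higher number from compound 1 to compound 2 (0.27 log units; within the scatter). Compound 3 differs from compound 2 in one place, with methoxy in place of phenyl on an aromatic carbon, para to a large group: methoxy in place of phenyl on an aromatic carbon. Put another way, 4-phenylphenyl gives way to 4-methoxyphenyl.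

Going by the values given here, only one measured step bears on this change, the one that brought phenyl in place of hydrogen at this same place. Among the compounds with values here, it was small, and no measured compound carries methoxy, so the evidence is indirect. With only a 1.8-fold higher number from compound 1 to compound 2 (0.27 log units; within the scatter) to go on, no change beyond the scatter is expected in this assay, and no direction can be firmly assigned. The expected step is a 1.5-fold lower number from compound 2 to compound 3 (0.18 log units; within the scatter). For compound 3 the estimated value is 12000 nM, with an expected range from 6000 nM to 25000 nM.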

Compound 3, half-maximal inhibitory concentration: 46800 nM
Estimate against measurement, compound 3: 3.9-fold (0.59 log units) below; measured number above the stated range.
By their numbers in this assay, from the lowest: compounds 1 and 2 (each within the scatter of the next); then compound 3.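

In this assay, going by these compounds alone, the earlier compounds had suggested that this place on the aromatic ring was indifferent to its substituent, since the only measured change there was a 1.8-fold higher number from compound 1 to compound 2 (0.27 log units; within the scatter) and so could not be told from noise. Methoxy now shows otherwise: it gives a 2.6-fold higher number from compound 2 to compound 3 (0.41 log units; beyond the scatter) and, against the unsubstituted ring, a 4.7-fold higher number from compound 1 to compound 3 (0.67 log units; beyond the scatter), so both steps point to weaker inhibition and this place does respond to what it carries, if only modestly. The response does not run in line with the size of the group, as methoxy, which has fewer heavy atoms than phenyl, does not fall between hydrogen and phenyl but lies on the weak side of both, and no information on the cause of this accompanies these values.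

With methoxy the only oxygen-bearing group at this place, the compounds shown leave open whether the loss belongs to methoxy alone or would also appear with a hydroxyl, an ethoxy group or a fluorine atom. They also leave open whether an amine or a carboxylic acid at the same place would move the number in the other direction.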